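Extending a prenyl chain, then swapping methoxy for benzyloxy

This account rests on a few compounds, and the source may have more. Where it says the series, first, only, none or still open, it means among the compounds named here.

Compound 1, `CO/N=c1\[nH]cnc2c1[n+](C/C=C(\C)CCC=C(C)C)cn2C`, in a functional assay on ACHN cells (Homo sapiens) for cytotoxicity (a higher number here means a weaker inhibitor, a lower number a stronger inhibitor), reaches only a limit, > 80000 nM.
Compound 2, `CO/N=c1\[nH]cnc2c1[n+](C/C=C(\C)CC/C=C(/C)CCC=C(C)C)cn2C`, in this assay gives 28700 nM.

Within the data shown here, compound 2 holds the only real number among the two values: the other is a limit, (the limit of > 80000 nM in this assay, at which 1 of the 2 values shown sits). Among the measured compounds shown here, the one measured step, an at least 2.7-fold lower number from compound 1 to compound 2 (0.44 log units; beyond the scatter), lengthens the chain on the charged core and gives a modest gain, though its size can only be bounded, since compound 1 sits at the limit.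

Compound 3, `CC(C)=CCC/C(C)=C\CC/C(C)=C/C[n+]1cn(C)c2nc[nH]/c(=N\OCc3ccccc3)c21`, keeps the long chain of compound 2 and changes another place: phenyl in place of hydrogen on a saturated chain carbon bound to an oxygen. For the measured compounds named here, no measured step touches this part of the molecule, and the step from compound 1 to compound 2 concerns a different chain, so it gives no direct guide. With nothing to point either way, the expected step is a 1.9-fold lower number from compound 2 to compound 3 (0.28 log units; within the scatter), a modest move that could also fall within the scatter. Compound 3 is therefore estimated at 15000 nM, with a range from 4000 nM to 50000 nM.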

Compound 3, half-maximal inhibitory concentration: 25200 nM
Beside the measured number, compound 3's estimate is 1.7-fold (0.23 log units) below it; the range from low to high includes it.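

Replacing methoxy with benzyloxy adds a six-membered aromatic ring of carbon on a saturated chain carbon bound to an oxygen, yet the result is a 1.1-fold lower number from compound 2 to compound 3 (0.06 log units; within the scatter), so this assay does not separate the two compounds. The earlier pair showed only what a change in the chain on the charged core can do, whereas this pair shows that, with the long chain in place, the oxygen substituent can grow from methyl to benzyl without a change beyond the usual scatter, while the chain step remains the only one shown to go beyond it. Nothing shown here bears on why the added ring leaves the number within the scatter.

Going by these compounds, whether this holds for other groups at the same place remains open: a hydroxy group, an ethoxy group or a longer chain ending in phenyl could each move the number differently from methoxy and benzyloxy. On these data alone, it is also open whether benzyloxy would give the same reading on the shorter chain of compound 1, since this comparison rests on the long chain alone.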